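The compounds below may be only part of what the source reports. "The series", "measured", "known", "first", "only" and "open" are said of these compounds alone.

Compound 1, with the structure `CC1(C)[C@@H]2CC[C@@]1(CS(=O)(=O)N1CCN(c3ccc(C(F)(F)F)cn3)CC1)C(F)C2`, is the starting point of this step. Among the compounds with values here, in a functional assay on CHO-K1 cells for antagonist activity at C-X-C chemokine receptor type 3 (Homo sapiens), read by FLIPR and calcium flux (on this read-out higher numbers stand for weaker inhibition and lower numbers for stronger inhibition), compound 1 gives 794 nM, the highest of the two numbers measured so far. Within the data shown here, the only other measured compound, compound 2, with the structure `CC1(O)C[C@H]2CC[C@]1(CS(=O)(=O)N1CCN(c3ccc(C(F)(F)F)cn3)CC1)C2(C)C`, gives 200 nM in this assay, a lower number and one that lies beyond the usual scatter of repeated runs; the two structures differ in more than one place, so the pair shows only that a compound of this shared core can reach a lower number than compound 1.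

The compound now considered is compound 3, with the structure `CC(=O)NC1C[C@H]2CC[C@]1(CS(=O)(=O)N1CCN(c3ccc(C(F)(F)F)cn3)CC1)C2(C)C`. It differs from compound 1 in one place: acetamido in place of fluoro on a saturated ring carbon. Among the measured compounds shown here, no measured pair shows a single change of this kind, so the size of the step is uncertain. The expectation for compound 3 is a modest move toward a lower number, because compound 2 at 200 nM shows that the core tolerates a change at this part of the ring without losing activity; the expected step is a 2.0-fold lower number from compound 1 to compound 3 (0.30 log units; within the scatter). Compound 3 is therefore estimated at 400 nM in this assay, within a range from 100 nM to 1600 nM.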

Compound 3, half-maximal inhibitory concentration: 2000 nM
For compound 3 the middle estimate is 5.0-fold (0.70 log units) below the measured one; measured number above the stated range.
By their numbers in this assay, from the lowest: compound 2; then compound 1; then compound 3.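

In this assay, within the data shown here, putting acetamido in place of fluoro on this saturated ring carbon gives a 2.5-fold higher number from compound 1 to compound 3 (0.40 log units; beyond the scatter) and so provides the first single change that can be read at this position. The ring carbon is therefore not indifferent to what it carries: here, the group with more heavy atoms, a hydrogen-bond donor and a hydrogen-bond acceptor goes with a higher number, which means weaker inhibition. No measurement shown here explains the rise.

Going by these compounds, a single step cannot separate the possible contributions of the amide hydrogen, the carbonyl and the overall size of the acetamido group, so which of these features matters remains open. An amine, a methoxy group or a longer amide such as propionamido on the same ring carbon would test these features one at a time and show whether the higher number is specific to acetamido or extends to other groups at this position.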